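A Larger Group on the Carbonyl Carbon of Compound 3

The compounds below may be only part of what the source reports. "The series", "measured", "known", "first", "only" and "open" are said of these compounds alone.

Measured so far in a functional assay on EC9706 cells (Homo sapiens) for cytotoxicity, read by MTT assay, with a stated time of 72 h; a lower number here means a stronger inhibitor, a higher number a weaker inhibitor:
- Compound 1, `O=C(CSC(=S)N[C@H]1CCOC1=O)Nc1ccc(Cl)cc1`: compound 1 gives > 128000 nM, a limit of the assay rather than a number.
- Compound 2, `COc1ccc(NC(=O)CSC(=S)N[C@H]2CCOC2=O)cc1`: compound 2 gives > 128000 nM, again a limit of the assay.
- Compound 3, `CCOC(=O)c1ccc(NC(=O)CSC(=S)N[C@H]2CCOC2=O)cc1`: compound 3 gives 112000 nM.

Going by the values given here, compound 3 thus holds the only actual number among the three; the other two values sit at the assay limit, as stated in the limit of > 128000 nM in this assay, at which 2 of the 3 values shown sit. The steps that lead to compound 3 are small: an at least 1.1-fold lower number from compound 1 to compound 3 (0.05 log units; that floor lies within the scatter) and an at least 1.1-fold lower number from compound 2 to compound 3 (0.05 log units; that floor lies within the scatter), and a step that the two limits leave unreadable from compound 1 to compound 2. All of them swap one substituent on an aromatic carbon.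

Compound 4, `O=C(CSC(=S)N[C@H]1CCOC1=O)Nc1ccc(C(=O)/C=C/c2cccc(Cl)c2)cc1`, changes a different place: 2-(3-chlorophenyl)ethenyl in place of ethoxy on a carbonyl carbon. Among the compounds with values here, none of the measured steps touches this carbonyl carbon, so they give no direct guide, and the entering group is far larger than anything swapped so far. A step beyond the scatter toward a lower number is expected, but with wide uncertainty. Compound 4 is estimated at 25000 nM, within 4000 nM to 128000 nM, which would mean a 4.5-fold lower number from compound 3 to compound 4 (0.65 log units; beyond the scatter).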

Compound 4, half-maximal inhibitory concentration: 32500 nM
Estimate against measurement, compound 4: 1.3-fold (0.11 log units) below; measured number inside the range.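

In this assay, replacing ethoxy with 2-(3-chlorophenyl)ethenyl on this carbonyl carbon gives a 3.4-fold lower number from compound 3 to compound 4 (0.54 log units; beyond the scatter). Going by these compounds alone, this is the first step here that is printed as beyond the scatter, so a change at this carbonyl carbon can move the number measurably, though the effect remains modest and compound 4 still needs a high concentration. The earlier swaps on an aromatic carbon gave only floors within the scatter or steps that cannot be read, and assay limits still mark part of the set: the limit of > 128000 nM in this assay, at which 2 of the 4 values shown sit.

This single step cannot separate the contributions of the aromatic ring, the double bond and the chlorine in the entering group. A plain 2-phenylethenyl group, a saturated two-carbon chain carrying the same ring, or an amine on the carbonyl carbon would each test a different part of that question.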